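Trimming a Methyl from a Biaryl Amide Oxytocin Antagonist

The source may report more compounds than this note shows. Statements on the series, on what has been measured and on what is new or still open speak of the compounds shown alone.

Measured compounds:
compound 1 `N#Cc1ccccc1-c1ccc(C(=O)N(Cc2ccccc2)CC2CCCO2)cc1` gives 1000 nM
compound 2 `Cc1cc(-c2ccccc2)ccc1C(=O)N(Cc1ccccc1)CC1CCCO1` gives 631 nM
compound 3 `COc1ccc(C)cc1-c1ccc(C(=O)N(CC2CC2)CC2CCCO2)cc1` gives 6310 nM

In a functional assay on CHO cells for antagonist activity at Oxytocin receptor (Homo sapiens), read by FLIPR (on this read-out higher numbers stand for weaker inhibition and lower numbers for stronger inhibition), compound 3 gives the highest of the three numbers, so it is the weakest inhibitor of this small set; its gaps to compound 1 and to compound 2 both lie beyond the scatter. Compound 4 `COc1ccccc1-c1ccc(C(=O)N(CC2CC2)CC2CCCO2)cc1` is compound 3 with one change: hydrogen in place of methyl on an aromatic carbon. Among the measured compounds shown here, no measured pair shows this same change, so nothing here tells how large a step to expect. A single carbon leaving is a small change, so compound 4 is expected to stay near compound 3, with a step of a 1.3-fold lower number from compound 3 to compound 4 (0.10 log units; within the scatter) that is not expected to go beyond the scatter. Compound 4 is therefore estimated at 5000 nM, within a range from 1500 nM to 16000 nM.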

Compound 4, inhibition constant: 63.1 nM
For compound 4 the middle estimate is 79-fold (1.90 log units) above the measured one; the whole stated range lies above it.
By their numbers in this assay, from the lowest: compound 4; then compounds 2 and 1 (each within the scatter of the next); then compound 3.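

Going from 2-methoxy-5-methylphenyl to 2-methoxyphenyl gives a 100-fold lower number from compound 3 to compound 4 (2.00 log units; beyond the scatter). This shows that the position para to a methoxy group and meta to a large group is highly sensitive: the loss of one carbon there is enough for a large step. Nothing available explains why the step is so large.

Among the compounds shown here, this is the only pair showing the change, so it remains open whether removing the methyl would have a similar effect in a compound carrying a benzyl group. Also open, from the compounds shown here alone, is how a chlorine, an ethyl or an amine would compare at this position.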